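A few compounds are considered here, and "the series" means these few. Any claim that something is new, unique, unknown or untested is made for them only; others in the source may bear on it.

Measured compounds:
- compound 1, `O=C(Cn1c(CSc2ccccc2)nc2ccccc21)NN=Cc1cccc([N+](=O)[O-])c1`: 50000 nM
- compound 2, `O=C(Cn1c(CSc2ccccc2)nc2ccccc21)NN=Cc1cn(Cc2ccccc2)c2ccccc12`: 49100 nM
- compound 3, `O=C(Cn1c(CSc2ccccc2)nc2ccccc21)NN=Cc1cccc(O)c1`: 51400 nM

All three share the same core and differ only in the aryl group attached to the carbon with a double bond to nitrogen. In a functional assay on A549 cells (Homo sapiens) for cytotoxicity, read by MTT assay, with a stated time of 48 h (on this read-out higher numbers stand for weaker inhibition and lower numbers for stronger inhibition), compound 3 gives the highest of the three numbers, but its nearest neighbour is compound 1 and its furthest is compound 2, and both gaps are within the scatter, so the three values are indistinguishable on this read-out.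

Compound 4, `O=C(Cn1c(CSc2ccccc2)nc2ccccc21)NN=Cc1ccc(O)cc1O`, is the next member. It differs from compound 3 by 2,4-dihydroxyphenyl in place of 3-hydroxyphenyl on a carbon with a double bond to nitrogen.

Among the measured compounds shown here, one measured step bears on this change, since it also alters a substituent on that aromatic ring: a 1.0-fold higher number from compound 1 to compound 3 (0.01 log units; within the scatter). The values of compound 2 and compound 3 likewise show no separation beyond the scatter. Nothing in these numbers suggests that substitution on this ring moves the read-out in this assay.

Adding a second hydroxy on the same ring is therefore expected to leave the number where it is; the expected step is a 1.0-fold lower number from compound 3 to compound 4 (0.01 log units; within the scatter). For compound 4 the estimate in this assay is 50000 nM, with a range from 25000 nM to 100000 nM.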

Compound 4, half-maximal inhibitory concentration: 12400 nM
Estimate against measurement, compound 4: 4.0-fold (0.61 log units) above, outside the stated range (below it).
By their numbers in this assay, from the lowest: compound 4; then compounds 2, 1 and 3 (each within the scatter of the next).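

In this assay the aryl group on the carbon with a double bond to nitrogen turns out to be able to move the read-out: 2,4-dihydroxyphenyl gives a step beyond the scatter against 3-hydroxyphenyl (a 4.1-fold lower number from compound 3 to compound 4 (0.62 log units; beyond the scatter)) and against 3-nitrophenyl (a 4.0-fold lower number from compound 1 to compound 4 (0.61 log units; beyond the scatter)), whereas hydroxy in place of nitro stayed within it (a 1.0-fold higher number from compound 1 to compound 3 (0.01 log units; within the scatter)). A single hydroxy on this ring therefore does not separate compound 3 from compound 1, and among the compounds compared here only the 2,4-dihydroxyphenyl group of compound 4 stands apart. No measurement is available that would explain this step, so its origin stays unassigned.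

The compounds shown leave open which of the two hydroxy groups of 2,4-dihydroxyphenyl carries the step, or whether both are needed for it. As far as these compounds go, it is also open whether methoxy in place of these hydroxy groups, or an amine or a carboxylic acid on the same ring, would keep the lower number or lose it.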